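A few compounds are considered here, and "the series" means these few. Any claim that something is new, unique, unknown or untested is made for them only; others in the source may bear on it.

In a functional assay on Vero cells (Chlorocebus sabaeus) for inhibition (a higher number here means a weaker inhibitor, a lower number a stronger inhibitor), compound 2 `Fc1ccc(Cn2cnc3c(-c4ccco4)ncnc32)cc1` gives > 10 ug/mL, which is a limit of the assay and not a number. Where compound 2 carries fluoro, compound 1 `CSc1ccc(Cn2cnc3c(-c4ccco4)ncnc32)cc1` carries methylsulfanyl and gives 6.9 ug/mL. Compound 3 `COc1ccc(Cn2cnc3c(-c4ccco4)ncnc32)cc1` differs from compound 2 by one change, methoxy in place of fluoro on an aromatic carbon, para to a large group. Among the measured compounds shown here, only one measured step bears on this change. That step, an at least 1.4-fold higher number from compound 1 to compound 2 (0.16 log units; that floor lies within the scatter), also puts fluoro on an aromatic carbon. Compound 3 loses that fluoro, so a small shift towards a lower number in this assay is expected, perhaps no larger than the scatter. For compound 3 the expected value is 8 ug/mL, with an estimated range of 3.5 ug/mL to 18 ug/mL. This estimate means an expected at least 1.2-fold lower number from compound 2 to compound 3 (0.09 log units; that floor lies within the scatter).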

Compound 3, half-maximal inhibitory concentration: > 62.5 ug/mL
Compound 3: a limit, no number; the forecaster's own chance of this, stated with the estimate: 45%; middle value at least 7.8-fold (0.89 log units) from the limit.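

On this aromatic carbon, para to a large group, replacing methylsulfanyl with methoxy in this assay gives an at least 9.0-fold higher number from compound 1 to compound 3 (0.95 log units; beyond the scatter), so this change, unlike the step to fluoro, is printed as beyond the scatter. Compound 3 gives > 62.5 ug/mL, which is a limit of the assay and not a number. Going by these compounds, compound 2 gives > 10 ug/mL, also a limit, so the step between the fluoro and methoxy compounds cannot be read and their order stays unknown.

Of the three compounds, only compound 1 gives a number, so one measured value is all that describes this position. On these data alone, whether a longer chain such as ethylsulfanyl, or an amine on the same aromatic carbon, would give a number rather than a limit in this assay remains open.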